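Acyl variation on the amidine series and the ring-nitrogen substituent

This account rests on a few compounds, and the source may have more. Where it says the series, first, only, none or still open, it means among the compounds named here.

Measured compounds:
- Compound 1, `CC(C)C(=O)N/C(=N/c1nccn1C(C)C)Nc1ccc(Cl)c(Cl)c1`. In an in vitro ADME assay on microsomes from liver (Homo sapiens) for metabolic stability, read by LC-MS, tested at 1 uM (a lower number here means that the compound disappears faster, a higher number that the compound lasts longer), compound 1 gives > 1 h, which is a limit of the assay.
- Compound 2, `CCC(CC)C(=O)N/C(=N/c1nccn1C(C)C)Nc1ccc(Cl)c(Cl)c1`. In this assay compound 2 gives > 1 h, a limit.
- Compound 3, `CC(C)n1ccnc1/N=C(/NC(=O)C(C)(C)C)Nc1ccc(Cl)c(Cl)c1`. In this assay compound 3 gives > 1 h, a limit.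

Compound 1 therefore stands only at the limit, and all three values shown sit there (the limit of > 1 h in this assay, at which 3 of the 3 values shown sit). The measured steps a step that the two limits leave unreadable from compound 1 to compound 2, a step that the two limits leave unreadable from compound 1 to compound 3 and a step that the two limits leave unreadable from compound 2 to compound 3 all change the acyl group on the carbonyl carbon and cannot be read in size.

Compound 4, `CC(C)C(=O)N/C(=N/c1nccn1Cc1ccccc1)Nc1ccc(Cl)c(Cl)c1`, differs from compound 1 by benzyl in place of isopropyl on an aromatic nitrogen. Among the measured compounds shown here, no measured step touches the aromatic nitrogen, so no direction can be drawn from the series. The expected step of a number no higher from compound 1 to compound 4 (the limit leaves the size open) is uncertain. Compound 4 is estimated at 1 h in this assay, with a range from 0.35 h to 3 h.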

Compound 4, half-life: 0.328 h
Compound 4: middle estimate off by 3.0-fold (0.48 log units), on the high side; measured number outside the range, below it.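

Benzyl in place of isopropyl on the aromatic nitrogen gives an at least 3.0-fold lower number from compound 1 to compound 4 (0.48 log units; beyond the scatter) in this assay and is the first change in the series whose size has a readable lower bound. This position therefore affects the half-life, whereas the acyl steps among compound 1, compound 2 and compound 3 cannot be read. Compound 4 is the only compound here that stands clear of the limit: the limit of > 1 h in this assay, at which 3 of the 4 values shown sit.

On these data alone, whether the drop follows the aromatic ring of the benzyl group or simply a larger group on this nitrogen stays open. A cyclohexylmethyl or a methyl group at the same nitrogen would separate the two readings, and the acyl groups remain unranked on the benzyl compound.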